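Cyclopropyl for Isopropyl on the Core Nitrogen

A few compounds are considered here, and "the series" means these few. Any claim that something is new, unique, unknown or untested is made for them only; others in the source may bear on it.

Compound 1 `CC(C)c1onc(-c2c(Cl)cccc2Cl)c1COc1ccc(-c2nc3cc(C(=O)O)ccc3n2C)cc1` gives 4410 nM in an assay on HEK-293T cells for antagonist activity at vitamin D3 receptor (Homo sapiens), read by a luciferase reporter, with a stated time of 24 h; on this read-out lower numbers stand for stronger inhibition and higher numbers for weaker inhibition.
Compound 2 `CC(C)c1onc(-c2c(Cl)cccc2Cl)c1COc1ccc(-c2nc3ccc(C(=O)O)cc3n2C(C)C)cc1` gives 3550 nM in this assay.
Compound 3 `CCC(CC)n1c(-c2ccc(OCc3c(-c4c(Cl)cccc4Cl)noc3C(C)C)cc2Cl)nc2ccc(C(=O)O)cc21` gives 1010 nM in this assay.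

On these three numbers compound 2 stands second highest. Its value and that of compound 1 lie within the scatter of each other, so no order between them can be read; compound 3 sits at a lower number, beyond the scatter. Compound 4 `CC(C)c1onc(-c2c(Cl)cccc2Cl)c1COc1ccc(-c2nc3ccc(C(=O)O)cc3n2C2CC2)cc1` has not yet been measured. It differs from compound 2 in a single place: cyclopropyl in place of isopropyl on an aromatic nitrogen. For the measured compounds named here, no pair of measured compounds shows this swap on its own, so the data give no direction for it. Compound 4 is therefore expected to stay close to compound 2, with a step of a 1.1-fold lower number from compound 2 to compound 4 (0.05 log units; within the scatter) that remains within the scatter. The estimate for compound 4 in this assay is 3200 nM, with a range from 1200 nM to 8500 nM.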

Compound 4, half-maximal inhibitory concentration: 3200 nM
For compound 4 middle estimate and measured number coincide at the digits printed, within the range that was stated.
By their numbers in this assay, from the lowest: compound 3; then compounds 4, 2 and 1 (each within the scatter of the next).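

For the compounds shown here, this is the first single-place step: in this assay, cyclopropyl in place of isopropyl on an aromatic nitrogen gives a 1.1-fold lower number from compound 2 to compound 4 (0.05 log units; within the scatter) and so leaves no readable difference. At this position, then, closing the three carbons into a three-membered ring, with the heavy-atom count unchanged, does not separate the two compounds. No supporting evidence bears on this result.

Still open, as far as these compounds go, is whether a phenyl ring or a hydroxyethyl chain on this nitrogen would move the number beyond the scatter.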